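From ethoxy to azido on a shared core

The source may report more compounds than this note shows. Statements on the series, on what has been measured and on what is new or still open speak of the compounds shown alone.

Measured so far in a functional assay on KB cells (Homo sapiens) for inhibition; on this read-out higher numbers stand for weaker inhibition and lower numbers for stronger inhibition:
- compound 1 `CC(=O)OC1C(CI)OC(n2c(Cl)nc3cc(Cl)c(Cl)cc32)C1OC(C)=O` gives 60000 nM
- compound 2 `CC(=O)OC1C(CN=[N+]=[N-])OC(n2c(Cl)nc3cc(Cl)c(Cl)cc32)C1OC(C)=O` gives 70000 nM
- compound 3 `CCOC[C@H]1OC(n2c(Cl)nc3cc(Cl)c(Cl)cc32)[C@H](O)[C@@H]1O` gives 80000 nM

Compound 3, at 80000 nM, lies within the scatter of compound 1 and compound 2, so it stands level with both. Compound 4 `[N-]=[N+]=NC[C@H]1OC(n2c(Cl)nc3cc(Cl)c(Cl)cc32)[C@H](O)[C@@H]1O` has not yet been measured. It carries azido in place of ethoxy on a saturated chain carbon bound to a saturated ring carbon.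

Among the compounds with values here, only one measured step bears on this change: a 1.2-fold higher number from compound 1 to compound 2 (0.07 log units; within the scatter). It also brings in azido at that place, though in place of iodo, and compound 1 and compound 2 differ from compound 3 elsewhere as well, so it is only a loose guide. Compound 2, which already holds the azido group, gives 70000 nM. No step beyond the scatter is therefore expected in this assay. The expected change is a 1.1-fold lower number from compound 3 to compound 4 (0.06 log units; within the scatter). For compound 4 the estimated value is 70000 nM, with an expected range from 30000 nM to 150000 nM.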

Compound 4, half-maximal inhibitory concentration: 70000 nM
The estimate for compound 4 equals the measured number at the digits printed; the range from low to high includes it.
By their numbers in this assay, from the lowest: compounds 1, 2, 4 and 3 (each within the scatter of the next).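

In this assay, replacing ethoxy with azido on a saturated chain carbon bound to a saturated ring carbon gives a 1.1-fold lower number from compound 3 to compound 4 (0.06 log units; within the scatter) and so leaves the read-out level on the core that carries free hydroxyl groups. Together with a 1.2-fold higher number from compound 1 to compound 2 (0.07 log units; within the scatter) on the acetylated core, two different groups have now given way to azido at this place without a step beyond the scatter. No measurement shown here explains why this exchange leaves the number level.

The compounds shown leave open whether an amine, a carboxylic acid or a longer chain at this place would produce a step beyond the scatter. They also leave open whether the exchange of ethoxy for azido would stay this small in a read-out other than this assay.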